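Isoxazole ester series: cytotoxicity on Vero cells, step to compound 4

This account rests on a few compounds, and the source may have more. Where it says the series, first, only, none or still open, it means among the compounds named here.

Measured compounds:
Compound 1 `CCOC(=O)c1cc(-c2cccc(OCc3cccc(F)c3)c2)on1` gives > 128000 nM in an ADME assay on Vero cells (Chlorocebus sabaeus) for cytotoxicity, with a stated time of 72 h; a higher number here means a weaker inhibitor, a lower number a stronger inhibitor; this is a limit of the assay, not a number.
Compound 2 `CCOC(=O)c1cc(-c2cccc(OCc3cccc(Br)c3)c2)on1` gives > 128000 nM in this assay; again a limit.
Compound 3 `CCOC(=O)c1cc(-c2cccc(OCc3ccccc3Cl)c2)on1` gives > 128000 nM in this assay; again a limit.

Compound 3 therefore stands only at a limit, and the two other values shown are limits as well, so nothing in the set separates one compound from another (the limit of > 128000 nM in this assay, at which 3 of the 3 values shown sit). The measured steps are a step that the two limits leave unreadable from compound 1 to compound 2, a step that the two limits leave unreadable from compound 1 to compound 3 and a step that the two limits leave unreadable from compound 2 to compound 3; none of them has a readable size, because every value involved sits at the same limit (the limit of > 128000 nM in this assay, at which 3 of the 3 values shown sit).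

The unmeasured compound 4 `CCOC(=O)c1cc(-c2cccc(OCc3cc(F)cc(F)c3)c2)on1` differs from compound 3 by 3,5-difluorophenyl in place of 2-chlorophenyl on a saturated chain carbon bound to an oxygen on an aromatic ring. The measured steps that change the same group on the saturated chain carbon bound to the oxygen on the aromatic ring all remain unreadable, so no shift beyond the scatter can be expected from them in this assay; the expected step is a step that the limit leaves unreadable from compound 3 to compound 4, read as no change from the limit. Compound 4 is estimated at 150000 nM, with an expected range from 90000 nM to 400000 nM, most likely again reported only as a limit.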

Compound 4, half-maximal inhibitory concentration: > 128000 nM
Compound 4 gave a limit, no number; the forecaster's own chance of this, stated with the estimate: 85%; the middle value is on the limit's open side.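

Compound 4 adds no readable step to compound 1, compound 2 or compound 3 in this assay, because every value is a limit and not a number: the limit of > 128000 nM in this assay, at which 4 of the 4 values shown sit.

The compounds shown leave open how these four rank in this assay, and whether any change to the shared core would give a number there rather than a limit.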